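This account rests on a few compounds, and the source may have more. Where it says the series, first, only, none or still open, it means among the compounds named here.

Measured so far in a functional assay on TSU-Pr1 cells for antiproliferative activity against TSU (Homo sapiens), read by sulforhodamine B assay; on this read-out lower numbers stand for stronger inhibition and higher numbers for weaker inhibition: compound 1 `CCCCCCCCCCCCCCCCCCNC(=O)[C@H]1CSC(CCCCCCCCCCCC)N1` gives 10700 nM; compound 2 `CCCCCCCCCCCCCCCCCCNC(=O)[C@H]1CSC(c2ccc(Br)cc2)N1` gives 18300 nM.

In this assay compound 2 stands at the higher of the two numbers shown; its nearest neighbour is compound 1, and the step of a 1.7-fold higher number from compound 1 to compound 2 (0.23 log units; within the scatter) lies within the scatter, so the data do not separate the two. Compound 3 `CCCCCCCCCCCCCCCCCCNC(=O)[C@H]1CSC(c2ccc([N+](=O)[O-])cc2)N1` is not yet measured. It differs from compound 2 by nitro in place of bromo on an aromatic carbon. No measured step bears on a swap of bromo for nitro on the aromatic ring: the only step shown, a 1.7-fold higher number from compound 1 to compound 2 (0.23 log units; within the scatter), changes the group on a saturated ring carbon and lies within the scatter, and it says nothing about substitution of the aromatic ring. With nothing to set a direction, the expected step of a 1.1-fold lower number from compound 2 to compound 3 (0.06 log units; within the scatter) is none beyond the scatter. Compound 3 is therefore estimated at 16000 nM in this assay, with a range from 6000 nM to 42000 nM.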

Compound 3, half-maximal inhibitory concentration: 15900 nM
For compound 3 the middle estimate is 1.0-fold (0.00 log units) above the measured one, within the range that was stated.
By their numbers in this assay, from the lowest: compounds 1, 3 and 2 (each within the scatter of the next).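

In this assay, within the data shown here, the first change on the aromatic ring itself, para to a large group, gives a 1.2-fold lower number from compound 2 to compound 3 (0.06 log units; within the scatter), so nitro and bromo at this place are not separated, although they differ in size and in hydrogen-bond acceptors as counted. The step of a 1.5-fold higher number from compound 1 to compound 3 (0.17 log units; within the scatter) likewise leaves 4-nitrophenyl not separated from dodecyl on the saturated ring carbon, and with a 1.7-fold higher number from compound 1 to compound 2 (0.23 log units; within the scatter) this means that neither aryl group is told apart from the alkyl chain. No independent data bear on this result.

As far as these compounds go, whether an amine or a carboxylic acid on the same aromatic carbon would give a step beyond the scatter remains open. So does the effect of a shorter chain on the amide nitrogen, since all three compounds share the same long chain there.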